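A few compounds are considered here, and "the series" means these few. Any claim that something is new, unique, unknown or untested is made for them only; others in the source may bear on it.

Measured compounds:
Compound 1 `COc1cc2ccc(=O)oc2cc1OCCOc1no[n+]([O-])c1S(=O)(=O)c1ccccc1` gives 7240 nM in a functional assay on A549 cells (Homo sapiens) for inhibition, read by MTT assay, with a stated time of 48 h; a higher number here means a weaker inhibitor, a lower number a stronger inhibitor.
Compound 2 `COc1cc2ccc(=O)oc2cc1OCCCOc1no[n+]([O-])c1S(=O)(=O)c1ccccc1` gives 5450 nM in this assay.
Compound 3 `COc1cc2cc(NC(C)=O)c(=O)oc2cc1OCCOc1no[n+]([O-])c1S(=O)(=O)c1ccccc1` gives 8790 nM in this assay.

Compound 3 carries the highest of the three numbers, yet the gap to compound 1 is small, as the step of a 1.2-fold higher number from compound 1 to compound 3 (0.08 log units; within the scatter) shows, and the values of compound 2 and compound 3 also sit within the usual scatter of each other, so none of the three can be called a weaker or stronger inhibitor than the others.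

Compound 4 `COc1cc2cc(N)c(=O)oc2cc1OCCOc1no[n+]([O-])c1S(=O)(=O)c1ccccc1` differs from compound 3 in one place: hydrogen in place of acetyl on a nitrogen on an aromatic ring. For the measured compounds named here, only one measured step touches this part of the core, the step from compound 1 to compound 3, which added the whole acetamido group without moving the number beyond the scatter. Removing just the acetyl, which is part of that same group, is therefore expected to change little. The step of a 1.1-fold lower number from compound 3 to compound 4 (0.04 log units; within the scatter) is the expected outcome. For compound 4 the estimated value in this assay is 8000 nM, with a range from 3500 nM to 18000 nM.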

Compound 4, half-maximal inhibitory concentration: 5910 nM
Compound 4: the middle estimate sits 1.4-fold (0.13 log units) above what was measured; the measured number falls inside the stated range.
By their numbers in this assay, from the lowest: compounds 2, 4, 1 and 3 (each within the scatter of the next).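

In this assay, taking the acetyl off the nitrogen gives a 1.5-fold lower number from compound 3 to compound 4 (0.17 log units; within the scatter), and setting the resulting amino group against plain hydrogen gives a 1.2-fold lower number from compound 1 to compound 4 (0.09 log units; within the scatter). Together with the earlier acetamido step, this means that hydrogen, amino and acetamido on this aromatic carbon all give numbers within the scatter of one another, so these three groups cannot be told apart in this assay, whether the nitrogen carries the acetyl or not. No separate evidence bears on this result.

Going by these compounds, whether a carboxylic acid or a nitrile on this aromatic carbon would produce a step beyond the scatter remains open. On these data alone, it is also open whether an amino group here would give a similar number when combined with the longer chain of compound 2.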